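This account rests on a few compounds, and the source may have more. Where it says the series, first, only, none or still open, it means among the compounds named here.

Compound 1, `Cc1cc(Nc2cc(-c3cccs3)[nH]n2)n2nc(SCc3ccc(Br)cc3)nc2n1`: 5370 nM
Compound 2, `Cc1cc(Nc2cc(-c3ccccc3)[nH]n2)n2nc(SCc3ccccc3Br)nc2n1`: 3020 nM

Both compounds were tested in a functional assay on MCF7 cells (Homo sapiens) for inhibition, read by MTT assay, with a stated time of 72 h; on this read-out lower numbers stand for stronger inhibition and higher numbers for weaker inhibition. Compound 2 gives 3020 nM, the smaller of the two numbers, while compound 1 gives 5370 nM; the gap between them lies within the usual scatter of this assay, so the two cannot be told apart on these data.

The new compound 3, `Cc1cc(Nc2cc(-c3ccccc3)[nH]n2)n2nc(SCc3csc4ccccc34)nc2n1`, is derived from compound 2 by a single change: 1-benzothiophen-3-yl in place of 2-bromophenyl on a saturated chain carbon bound to a sulfur. The shared core and the remaining parts of compound 2 are kept. Among the compounds with values here, no step between measured compounds that differ in one place is available, so there is nothing in the data that tells how a change at this position affects the read-out.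

With only this to go on, the expected step is a 1.1-fold lower number from compound 2 to compound 3 (0.03 log units; within the scatter), a change that would not rise above the usual scatter in either direction. Compound 3 is therefore estimated at 2800 nM, with a range from 900 nM to 9000 nM.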

Compound 3, half-maximal inhibitory concentration: 3470 nM
Compound 3: middle estimate off by 1.2-fold (0.09 log units), on the low side, within the range that was stated.
By their numbers in this assay, from the lowest: compounds 2, 3 and 1 (each within the scatter of the next).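

Within the data shown here, this is the first step that can be read at this position. In this assay, putting 1-benzothiophen-3-yl in place of 2-bromophenyl on a saturated chain carbon bound to a sulfur gives a 1.1-fold higher number from compound 2 to compound 3 (0.06 log units; within the scatter) and so leaves the two groups indistinguishable. The change is not a small one on paper. A single aromatic ring with a bromine and 7 heavy atoms gives way to two aromatic rings with a sulfur, 9 heavy atoms and 1 hydrogen-bond acceptor, yet the read-out shows no real difference, and nothing measured here offers an explanation for that.

As far as these compounds go, both groups are aromatic, so it remains open whether this position would stay as indifferent to an amine, a carboxylic acid or a longer alkyl chain on the same sulfur. From the compounds shown here alone, it is also open how a plain phenyl without the bromine would read at this place, and whether any group there could move the number beyond the usual scatter in either direction.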